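From amino to methoxy at the assay limit

The source may report more compounds than this note shows. Statements on the series, on what has been measured and on what is new or still open speak of the compounds shown alone.

In a functional assay on A549 cells (Homo sapiens), read by MTT assay, with a stated time of 72 h (a lower number here means a stronger inhibitor, a higher number a weaker inhibitor), compound 1 `Nc1nc(N)c2c(-c3ccco3)cn([C@@H]3O[C@H](CO)[C@@H](O)[C@H]3O)c2n1` reads only as a limit, > 20000 nM. Compound 2 `Nc1nc(N)c2c(-c3cc4ccccc4o3)cn([C@@H]3O[C@H](CO)[C@@H](O)[C@H]3O)c2n1` also reads only as a limit, > 20000 nM. The series thus stands at the limit of > 20000 nM in this assay, at which 2 of the 2 values shown sit. Among the measured compounds shown here, the only measured step, a step that the two limits leave unreadable from compound 1 to compound 2, concerns a different group and gives no size for the next change. Compound 3 `COc1nc(N)nc2c1c(-c1ccco1)cn2[C@@H]1O[C@H](CO)[C@@H](O)[C@H]1O` differs from compound 1 by methoxy in place of amino on an aromatic carbon. No step beyond the scatter is expected in this assay, so no direction is predicted. The estimated value for compound 3 is 20000 nM, with an expected range from 6000 nM to 60000 nM. This expected value means a number no higher from compound 1 to compound 3 (the limit leaves the size open).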

Compound 3, half-maximal inhibitory concentration: > 20000 nM
Compound 3: a limit, no number; the forecaster's own chance of this, stated with the estimate: 75%; the middle value lies on the limit itself.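

In this assay, among the compounds shown here, compound 3 gives only a limit, > 20000 nM, so no step from compound 1 to it can be read. The compounds shown leave open whether methoxy and amino differ here, with every reading at the same limit: the limit of > 20000 nM in this assay, at which 3 of the 3 values shown sit.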